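From 3-fluorobenzyl to 4-chlorobenzyl in compound 4

The source may report more compounds than this note shows. Statements on the series, on what has been measured and on what is new or still open speak of the compounds shown alone.

Compound 1 `COc1ccc(Cc2nnc(NC(=O)/C(C#N)=C/c3ccccc3OS(=O)(=O)c3ccc(OC)cc3)s2)cc1`: 840 nM
Compound 2 `COc1ccc(S(=O)(=O)Oc2ccccc2/C=C(\C#N)C(=O)Nc2nnc(Cc3ccc(F)cc3)s2)cc1`: 1210 nM
Compound 3 `COc1ccc(S(=O)(=O)Oc2ccccc2/C=C(\C#N)C(=O)Nc2nnc(Cc3cccc(F)c3)s2)cc1`: 1210 nM

In a functional assay on RS4-11 cells (Homo sapiens) for inhibition, read by CCK-8 assay, with a stated time of 48 h (on this read-out lower numbers stand for stronger inhibition and higher numbers for weaker inhibition), compound 3 gives 1210 nM, the same number as compound 2 and within the scatter of compound 1. The next compound, compound 4 `COc1ccc(S(=O)(=O)Oc2ccccc2/C=C(\C#N)C(=O)Nc2nnc(Cc3ccc(Cl)cc3)s2)cc1`, differs from compound 3 in one place: 4-chlorophenyl in place of 3-fluorophenyl on a saturated chain carbon bound to an aromatic carbon. That is, 4-chlorophenyl stands in place of 3-fluorophenyl on a saturated chain carbon bound to an aromatic carbon.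

Three measured steps exchange a substituent on this aromatic ring: a 1.4-fold higher number from compound 1 to compound 2 (0.16 log units; within the scatter), a 1.4-fold higher number from compound 1 to compound 3 (0.16 log units; within the scatter) and no change at the digits printed from compound 2 to compound 3 (within the scatter). Within the data shown here, none of the measured compounds carries chlorine, so these steps are only an indirect guide. In this assay no shift beyond the scatter is therefore expected, and the estimated step is a 1.1-fold lower number from compound 3 to compound 4 (0.04 log units; within the scatter).

For compound 4 the estimated value is 1100 nM, with an expected range from 500 nM to 2400 nM.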

Compound 4, half-maximal inhibitory concentration: 1250 nM
The estimate for compound 4 lay 1.1-fold (0.06 log units) below the measured number; the range from low to high includes it.
By their numbers in this assay, from the lowest: compounds 1, 2, 3 and 4 (each within the scatter of the next).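

In this assay, chloro on this benzyl ring gives a 1.0-fold higher number from compound 3 to compound 4 (0.01 log units; within the scatter) and a 1.0-fold higher number from compound 2 to compound 4 (0.01 log units; within the scatter), so the first chlorine-bearing compound sits level with both fluoro compounds. Against the methoxy compound the step is a 1.5-fold higher number from compound 1 to compound 4 (0.17 log units; within the scatter), which means that methoxy, fluoro and chloro on this ring cannot be told apart here. Nothing available explains why these substituents read alike.

The compounds shown leave open whether an amine or a carboxylic acid on this ring, or a longer chain in place of the benzyl group, would move the number beyond the scatter.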